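Phenyl in place of methyl on a ring nitrogen

A few compounds are considered here, and "the series" means these few. Any claim that something is new, unique, unknown or untested is made for them only; others in the source may bear on it.

Measured so far:
compound 1, `COc1ccc(/C=C2\CN(C)CC3=C2OC(N)=C(C#N)C3c2ccc(OC)cc2)cc1`: 93900 nM
compound 2, `CN1C/C(=C\c2cccs2)C2=NN(C)C(c3cccs3)C2C1`: 97700 nM

In a functional assay on cells (Panel melanoma (Carcinoma cell lines), Homo sapiens) for inhibition (a lower number here means a stronger inhibitor of growth, a higher number a weaker inhibitor of growth), compound 2 gives 97700 nM, the higher of the two numbers recorded. Its nearest neighbour is compound 1, which in this assay gives 93900 nM, and the gap between the two lies within the usual scatter of repeated measurements, so the two compounds cannot be placed in any order. Among the measured compounds shown here, the two also differ in many places at once, so no single structural step between them is available.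

Compound 3, `CN1C/C(=C\c2cccs2)C2=NN(c3ccccc3)C(c3cccs3)C2C1`, is the next compound to be measured in this assay. It differs from compound 2 in one place: phenyl in place of methyl on an amine nitrogen in a ring.

For the measured compounds named here, with no measured step to lean on, the size of the change cannot be read from the data; the expectation is a step of no more than the scatter, in either direction. Compound 3 is therefore expected to give 80000 nM, with a range from 30000 nM to 200000 nM. That estimate means a step of a 1.2-fold lower number from compound 2 to compound 3 (0.09 log units; within the scatter), which is expected to stay within the scatter.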

Compound 3, concentration for total growth inhibition: > 100000 nM
Compound 3 was reported as a limit (the forecaster's own chance of this, stated with the estimate: 25%); at least 1.2-fold (0.09 log units) between middle value and limit.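

In this assay compound 3 gives > 100000 nM, which is a limit of the assay and not a number: the limit of > 100000 nM in this assay, at which 1 of the 3 values shown sits.

Among the compounds shown here, this provides the first single-place step, phenyl in place of methyl on an amine nitrogen in a ring, and that step reads an at least 1.0-fold higher number from compound 2 to compound 3 (0.01 log units; that floor lies within the scatter). For the compounds shown here, the earlier compounds could not show this, as they differ in many places at once, whereas here the result shows that phenyl at this ring nitrogen does not give a stronger inhibitor of growth than methyl, although the true size of the step remains unknown.

The compounds shown leave open whether any other group on this ring nitrogen, such as a hydrogen, a benzyl or an acetyl, would bring the number down from that of compound 2. They also leave open whether the same exchange would behave alike with a group other than thiophen-2-yl on the neighbouring ring atom, for instance a furan-2-yl group.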